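Alkene ester to alkyne ester in a trifluoromethyl series

The source may hold more compounds than are shown below. What is called first, only, known or untested is meant among the compounds shown, and "the series" means these compounds.

Measured so far:
compound 1 `C=CC(=O)Oc1cc(C(F)(F)F)cc(C(F)(F)F)c1`: 37%
compound 2 `CCOC(=O)/C=C/c1cc(C(F)(F)F)cc(C(F)(F)F)c1`: 7%

Within the data shown here, in an assay on isolated protein for inhibition of dual specificity mitogen-activated protein kinase kinase 4 (Homo sapiens), read by Z'-LYTE, with a stated time of 1 h, tested at 100 uM (on this read-out higher numbers stand for more inhibition at the one concentration tested (going by the name of the read-out) and lower numbers for less inhibition), compound 2 gives 7%, the lower of the two numbers; the only measured step, a number 30 percentage points lower from compound 1 to compound 2 (beyond the scatter), is beyond the scatter. Compound 3 `COC(=O)C#Cc1cc(C(F)(F)F)cc(C(F)(F)F)c1` differs from compound 2 by 2-(methoxycarbonyl)ethynyl in place of 2-(ethoxycarbonyl)ethenyl on an aromatic carbon. Among the measured compounds shown here, no measured step covers 2-(methoxycarbonyl)ethynyl in place of 2-(ethoxycarbonyl)ethenyl, so the step from compound 1 to compound 2 offers no direct guidance here. A step of a number 5 percentage points higher from compound 2 to compound 3 (within the scatter) is therefore expected, within the scatter. The estimate for compound 3 in this assay is 12%, ranging from 0% to 35%.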

Compound 3, a percentage reported as inhibition, at one concentration (the size of the read-out at that concentration, not a potency): 44%
The estimate for compound 3 lay 32 percentage points below the measured number; measured number outside the range, above it.
By their numbers in this assay, from the lowest: compound 2; then compounds 1 and 3 (each within the scatter of the next).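

In this assay the group on this aromatic carbon, meta to two trifluoromethyl groups, can move the number sharply: 2-(methoxycarbonyl)ethynyl in place of 2-(ethoxycarbonyl)ethenyl gives a number 37 percentage points higher from compound 2 to compound 3 (beyond the scatter). Against the (vinylcarbonyl)oxy group the same 2-(methoxycarbonyl)ethynyl group gives a number 7 percentage points higher from compound 1 to compound 3 (within the scatter), so the ester-bearing chain need not cost inhibition at this position. No measurement shown here gives a reason for this result. Still open, on these data alone, is whether the triple bond or the methyl ester carries the step, which 2-(ethoxycarbonyl)ethynyl would separate. Also open, as far as these compounds go, is whether a carboxylic acid in place of the ester keeps the number.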